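Removing a chloro group from compound 3's dichlorophenyl arm

The compounds below may be only part of what the source reports. "The series", "measured", "known", "first", "only" and "open" are said of these compounds alone.

Measured compounds in an ADME assay on L6 cells (Rattus norvegicus) for cytotoxicity, read by fluorescence and resazurin assay, with a stated time of 72 h; on this read-out higher numbers stand for lower toxicity in this test and lower numbers for higher toxicity in this test:
Compound 1 `Clc1ccc(C(c2c[nH]cc2-c2ccc(Cl)cc2-n2cccc2)n2ccnc2)c(Cl)c1`: 7670 nM
Compound 2 `Clc1ccc(C(c2c[nH]cc2-c2ccc(Cl)cc2-c2cccs2)n2ccnc2)c(Cl)c1`: 4930 nM
Compound 3 `Clc1ccc(C(c2c[nH]cc2-c2ccc(Cl)cc2-c2ccccc2)n2ccnc2)c(Cl)c1`: 14300 nM

Compound 3 gives the highest of the three numbers in this assay. The step of a 1.9-fold higher number from compound 1 to compound 3 (0.27 log units; within the scatter) does not separate the two compounds involved, while the step of a 2.9-fold higher number from compound 2 to compound 3 (0.46 log units; beyond the scatter) is a modest but real difference. The step of a 1.6-fold lower number from compound 1 to compound 2 (0.19 log units; within the scatter) also stays within the scatter.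

Compound 4 `Clc1ccc(C(c2c[nH]cc2-c2ccc(Cl)cc2-c2ccccc2)n2ccnc2)cc1` differs from compound 3 by hydrogen in place of chloro on an aromatic carbon, so the 2,4-dichlorophenyl becomes a 4-chlorophenyl. Among the measured compounds shown here, none of the measured steps touches this position; all three concern the group on the other aromatic ring, and the largest of them was only modest. There is thus no direct precedent for the change, and the small range of the three measured numbers gives no reason to expect a large move.

Compound 4 is therefore estimated at 13000 nM, with a range from 6000 nM to 28000 nM. The expected step of a 1.1-fold lower number from compound 3 to compound 4 (0.04 log units; within the scatter) would lie within the scatter, with no clear direction.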

Compound 4, half-maximal cytotoxic concentration: 14900 nM
Beside the measured number, compound 4's estimate is 1.1-fold (0.06 log units) below it; the measured number falls inside the stated range.
By their numbers in this assay, from the lowest: compounds 2, 1, 3 and 4 (each within the scatter of the next, the first and the last beyond it).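

In this assay, the change from 2,4-dichlorophenyl to 4-chlorophenyl gives a 1.0-fold higher number from compound 3 to compound 4 (0.02 log units; within the scatter), so hydrogen in place of chloro at this place, ortho to a large group, does not separate the two compounds. Among the compounds shown here, the earlier steps concerned only the group on the other aromatic ring, where a 2.9-fold higher number from compound 2 to compound 3 (0.46 log units; beyond the scatter) was the one step beyond the scatter, whereas this pair shows that, with phenyl on that other ring, one chloro group of the dichlorophenyl arm can be exchanged for hydrogen without a difference this test can resolve. No measured information here bears on why this exchange makes so little difference.

This single pair leaves open whether the same exchange would also go unnoticed with the thiophen-2-yl group of compound 2 or the 1H-pyrrol-1-yl group of compound 1, and whether the remaining chloro group matters to the read-out. It also leaves open whether a different replacement at this place, such as a methoxy group or an amine, would give a step beyond the scatter.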